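Dog plasma clearance in a quinoline-type series: fluoro on the phenyl

The source may report more compounds than this note shows. Statements on the series, on what has been measured and on what is new or still open speak of the compounds shown alone.

Measured so far:
- compound 1, `COc1cc2nc(N3CCCN(C(=O)N4CCOCC4)CC3)cc(N)c2c(-c2ccccc2)c1OC`: 88 mL/min/kg
- compound 2, `COc1cc2nc(N3CCc4ncccc4C3)nc(N)c2c(-c2ncccn2)c1OC`: 450 mL/min/kg

Two compounds have numbers in an in vivo ADME assay on the whole organism (plasma) for pharmacokinetics, with Canis familiaris (Canis lupus familiaris) as the target, at a dose of 0.5 mg/kg by the intravenous route; a lower number here means slower removal, a higher number faster removal of the compound. In this assay compound 1 gives 88 mL/min/kg, the lower of the two values. Compound 2 gives 450 mL/min/kg, a higher number than compound 1 by a margin beyond the scatter; the two differ in more than one place, so only the two values themselves are stated here.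

Compound 3, `COc1cc2nc(N3CCCN(C(=O)N4CCOCC4)CC3)cc(N)c2c(-c2ccc(F)cc2)c1OC`, is not yet measured in this assay. It differs from compound 1 by fluoro in place of hydrogen on an aromatic carbon; cut one bond further out, the change reads phenyl to 4-fluorophenyl. Among the compounds with values here, no measured pair shows this change, so no size or direction of step can be drawn from the data. The expectation for compound 3 is therefore a step close to that of compound 1, a 1.0-fold lower number from compound 1 to compound 3 (0.02 log units; within the scatter), with no direction beyond the scatter. Compound 3 is estimated at 85 mL/min/kg, with a range from 40 mL/min/kg to 180 mL/min/kg.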

Compound 3, clearance in the Canis familiaris assay: 536 mL/min/kg
Estimate against measurement, compound 3: 6.3-fold (0.80 log units) below; the whole stated range lies below it.
By their numbers in the Canis familiaris assay, from the lowest: compound 1; then compounds 2 and 3 (each within the scatter of the next).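

In the Canis familiaris assay, compound 1 gives 88 mL/min/kg and compound 3 gives 536 mL/min/kg. In the Canis familiaris assay, fluoro in place of hydrogen on the phenyl gives a 6.1-fold higher number from compound 1 to compound 3 (0.78 log units; beyond the scatter), the only one-place step shown so far, so this position on the phenyl is not silent for clearance. In a physicochemical assay for acid dissociation, compound 1 gives 8.5 and compound 3 gives 8.5. In the physicochemical assay, the same change gives no change at the digits printed from compound 1 to compound 3 (within the scatter), so this pair shows a clearance step without any accompanying step in the acid dissociation constant. Nothing available bears on the reason for the clearance step.

Going by these compounds, whether a chloro, a methoxy or a nitrile at the same place moves clearance in the same direction and by a similar amount remains open. Also open, on these data alone, is whether the step from phenyl to 4-fluorophenyl carries over to a core other than that of compound 1.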